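Swapping a small ring for a methylphenyl on the triazole

A few compounds are considered here, and "the series" means these few. Any claim that something is new, unique, unknown or untested is made for them only; others in the source may bear on it.

Of the compounds shown here, three sharing one core have been tested in a functional assay on HCT-116 cells (Homo sapiens) for antiproliferative activity, read by MTT assay, with a stated time of 72 h; a higher number here means a weaker inhibitor, a lower number a stronger inhibitor. Compound 1 `CCCCCc1ccc(-c2cn(C[C@H](O)[C@H]3OC(=O)C(OCc4ccccc4)=C3OCc3ccccc3)nn2)cc1` gives 13800 nM. Compound 3 `O=C1O[C@H]([C@@H](O)Cn2cc(C3CC3)nn2)C(OCc2ccccc2)=C1OCc1ccccc1` gives 30400 nM, the highest of the two plain numbers, and it sits a 2.2-fold higher number from compound 1 to compound 3 (0.34 log units; beyond the scatter). Compound 2 `COc1ccccc1-c1cn(C[C@H](O)[C@H]2OC(=O)C(OCc3ccccc3)=C2OCc2ccccc2)nn1` reached only the limit of this assay, > 100000 nM, a limit rather than a number (the limit of > 100000 nM in this assay, at which 1 of the 3 values shown sits). Against that limit, the step of an at least 3.2-fold lower number from compound 2 to compound 3 (0.51 log units; beyond the scatter) shows that a cyclopropyl on the triazole does better than a 2-methoxyphenyl there.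

Compound 4 `Cc1ccc(-c2cn(C[C@H](O)[C@H]3OC(=O)C(OCc4ccccc4)=C3OCc3ccccc3)nn2)cc1` has not yet been measured. Its difference from compound 3 is 4-methylphenyl in place of cyclopropyl on an aromatic carbon. For the measured compounds named here, two measured steps bear on this: moving from 4-pentylphenyl to cyclopropyl gave a 2.2-fold higher number from compound 1 to compound 3 (0.34 log units; beyond the scatter), while moving from 2-methoxyphenyl to cyclopropyl gave an at least 3.2-fold lower number from compound 2 to compound 3 (0.51 log units; beyond the scatter). A 4-methylphenyl resembles the 4-pentylphenyl of compound 1 more than the 2-methoxyphenyl of compound 2, so a modest fall in the number, roughly undoing the step from compound 1 to compound 3, seems the likelier outcome, though the case of compound 2 warns that an aryl ring can also push the value beyond the limit. The expected step is a 1.5-fold lower number from compound 3 to compound 4 (0.18 log units; within the scatter). Compound 4 is therefore estimated at 20000 nM, within a range from 8000 nM to 60000 nM.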

Compound 4, half-maximal inhibitory concentration: > 100000 nM
Compound 4 ended at the assay's limit; the forecaster's own chance of this, stated with the estimate: 10%; middle value at least 5.0-fold (0.69 log units) away from the limit.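

Putting 4-methylphenyl in place of cyclopropyl on the triazole gives an at least 3.2-fold higher number from compound 3 to compound 4 (0.51 log units; beyond the scatter), so an aryl ring at this position does not by itself improve on the small saturated ring. The chain carried by that aryl ring also counts: with hydrogen in place of butyl on the chain, the result in this assay is an at least 7.2-fold higher number from compound 1 to compound 4 (0.86 log units; beyond the scatter), and of the three aryl groups shown, only 4-pentylphenyl gives a plain number, while the non-aryl cyclopropyl of compound 3 gives one too. The result for compound 4 is a limit and not a number, like that of compound 2, so the step linking those two compounds cannot be read: the limit of > 100000 nM in this assay, at which 2 of the 4 values shown sit.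

As far as these compounds go, whether a propyl or an octyl chain in place of the pentyl of compound 1 would give a plain number, and a lower or higher one, stays open. So does whether an amine or a carboxylic acid at the end of that chain would keep the value of compound 1, and how far beyond the limit compound 4 truly lies.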